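This account rests on a few compounds, and the source may have more. Where it says the series, first, only, none or still open, it means among the compounds named here.

Compound 1 `Fc1ccc(Cn2cc(CCCOc3cccc4cccnc34)nn2)cc1` has the shared core carrying a 4-fluorobenzyl group on the ring nitrogen. In a functional assay on NCI/ADR-RES cells (Homo sapiens) for inhibition, read by sulforhodamine B assay, with a stated time of 48 h (on this read-out lower numbers stand for stronger inhibition of growth and higher numbers for weaker inhibition of growth), compound 1 gives 49.4 ug/mL, the highest of the three numbers measured. Compound 2 `Brc1ccc(Cn2cc(CCCOc3cccc4cccnc34)nn2)cc1` gives 25.8 ug/mL, and the step of a 1.9-fold lower number from compound 1 to compound 2 (0.28 log units; within the scatter) stays within the scatter. Compound 3 `Clc1ccc(Br)cc1Cn1cc(CCCOc2cccc3cccnc23)nn1` gives 2.5 ug/mL, and the step of a 20-fold lower number from compound 1 to compound 3 (1.30 log units; beyond the scatter) is large, as is a 10-fold lower number from compound 2 to compound 3 (1.01 log units; beyond the scatter).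

Compound 4 `c1cncc(CCCn2cc(CCCOc3cccc4cccnc34)nn2)c1` differs from compound 1 by 2-(pyridin-3-yl)ethyl in place of 4-fluorophenyl on a saturated chain carbon bound to an aromatic nitrogen. For the measured compounds named here, none of the measured steps bears directly on this change: the steps from compound 1 to compounds 2 and 3 alter the substituents of the aryl ring, whereas here the ring itself is replaced by a heteroaryl group and the spacer is lengthened. The data give no guidance on the direction, so compound 4 is expected to lie near compound 1, with the step of a 1.2-fold lower number from compound 1 to compound 4 (0.09 log units; within the scatter) expected to fall within the scatter but with a wide range. Compound 4 is therefore estimated at 40 ug/mL, between 10 ug/mL and 100 ug/mL.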

Compound 4, concentration for 50% growth inhibition: 12.5 ug/mL
Estimate against measurement, compound 4: 3.2-fold (0.51 log units) above; measured number inside the range.
By their numbers in this assay, from the lowest: compound 3; then compound 4; then compounds 2 and 1 (each within the scatter of the next).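

In this assay, for the compounds shown here, the earlier compounds varied only the halogens on a benzyl group, whereas 3-(pyridin-3-yl)propyl replaces that group altogether and the number still falls (a 4.0-fold lower number from compound 1 to compound 4 (0.60 log units; beyond the scatter)), and also falls against the 4-bromobenzyl compound (a 2.1-fold lower number from compound 2 to compound 4 (0.31 log units; beyond the scatter)). A halogenated benzyl group is therefore not needed at this place on the ring nitrogen for a number lower than those of the two singly halogenated compounds. The 5-bromo-2-chlorophenyl compound still gives the lowest number (a 5.0-fold higher number from compound 3 to compound 4 (0.70 log units; beyond the scatter)), and nothing shown offers an explanation for these steps.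

As far as these compounds go, the ring and the chain change together, so it stays open which of them carries the step; a 3-phenylpropyl group or a pyridin-3-ylmethyl group would separate them. From the compounds shown here alone, how an amine or a carboxylic acid would read at this place also stays open.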